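Hydroxy on the aryl ring of compound 1

The source may report more compounds than this note shows. Statements on the series, on what has been measured and on what is new or still open speak of the compounds shown alone.

Among the measured compounds shown here, in a functional assay on HepG2 cells (Homo sapiens) for antiproliferative activity, read by MTT assay, with a stated time of 48 h (a higher number here means a weaker inhibitor of growth, a lower number a stronger inhibitor of growth), compound 1 `COC(=O)N1N=C(c2ccccc2)CC1c1cc(OC)c(OC)c(OC)c1` gives 3950 nM, the only plain number in the set. Compound 2 `COc1cc(C2CC(c3ccccc3)=NN2C(=O)OCc2ccccc2)cc(OC)c1OC` reaches only the limit of > 10000 nM in this assay, at which 1 of the 2 values shown sits, and gives > 10000 nM, a limit rather than a number. For the measured compounds named here, the step of an at least 2.5-fold higher number from compound 1 to compound 2 (0.40 log units; beyond the scatter) is the sole measured step, and it concerns the chain carbon bound to oxygen, not the aryl ring. Compound 3 `COC(=O)N1N=C(c2cccc(O)c2)CC1c1cc(OC)c(OC)c(OC)c1` differs from compound 1 by hydroxy in place of hydrogen on an aromatic carbon. Going by the values given here, no measured step touches this aromatic position, so nothing here supports a move beyond the scatter. Compound 3 is therefore expected at 3500 nM, within 1400 nM to 9000 nM, an estimated step of a 1.1-fold lower number from compound 1 to compound 3 (0.05 log units; within the scatter).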

Compound 3, concentration for 50% growth inhibition: 650 nM
The estimate for compound 3 lay 5.4-fold (0.73 log units) above the measured number; measured number below the stated range.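

In this assay, the change from phenyl to 3-hydroxyphenyl gives a 6.1-fold lower number from compound 1 to compound 3 (0.78 log units; beyond the scatter), so this aromatic position responds to substitution, which the step on the chain carbon bound to oxygen could not show. Among the compounds shown here, of the two steps, this is the one that lowers the number. Nothing at hand accounts for this drop. Open, on these data alone, is whether the hydroxy itself is required, or whether an amine or a fluorine at this place would serve as well. Also open, as far as these compounds go, is how hydroxy behaves elsewhere on this ring.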